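Swapping furan for oxolane on the piperidine nitrogen

The source may report more compounds than this note shows. Statements on the series, on what has been measured and on what is new or still open speak of the compounds shown alone.

Three compounds share one core and were compared in an assay on HEK293 cells for displacement of a labelled ligand from growth hormone secretagogue receptor type 1 (Homo sapiens), with a stated time of 60 min; a higher number here means a weaker inhibitor, a lower number a stronger inhibitor. Compound 1 `Cc1ccccc1-c1nc2cn(-c3cccc(C#N)c3)nc2c(=O)n1CC1CCCN(C(C)C)C1` gives 32 nM. Compound 2 `Cc1ncccc1-c1nc2cn(-c3cccc(OC(C)C)c3)nc2c(=O)n1C[C@H]1CCCN(C[C@H]2CCCO2)C1` gives 11 nM. Compound 3 `COc1cccc(-n2cc3nc(-c4cccnc4C)n(C[C@H]4CCCN(Cc5ccco5)C4)c(=O)c3n2)c1` gives 2.7 nM, the lowest of the three numbers; its gap to compound 2 and its larger gap to compound 1 both lie beyond the usual scatter, so compound 3 is the strongest of the measured set.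

Compound 4 `COc1cccc(-n2cc3nc(-c4cccnc4C)n(C[C@H]4CCCN(CC5CCOC5)C4)c(=O)c3n2)c1` is not yet measured. It differs from compound 3 in one place: oxolan-3-yl in place of furan-2-yl on a saturated chain carbon bound to an amine nitrogen in a ring. The aromatic five-membered ring gives way to a saturated one of the same size and with the same single oxygen, attached through a different ring atom.

Within the data shown here, no measured pair shows this exact exchange, so the direction is uncertain. A modest weakening is expected, with the step from compound 3 to compound 4 estimated at a 2.2-fold higher number from compound 3 to compound 4 (0.35 log units; beyond the scatter). Compound 4 is therefore expected to give about 6 nM in this assay, within a range of 2 nM to 20 nM.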

Compound 4, half-maximal inhibitory concentration: 60 nM
The estimate for compound 4 lay 10-fold (1.00 log units) below the measured number; measured number above the stated range.
By their numbers in this assay, from the lowest: compound 3; then compound 2; then compounds 1 and 4 (each within the scatter of the next).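

In this assay, among these compounds, the exchange of furan-2-yl for oxolan-3-yl gives a 22-fold higher number from compound 3 to compound 4 (1.35 log units; beyond the scatter) in a single change, the only comparison in this set that differs in one place. It shows that this position on the piperidine nitrogen's chain responds strongly to the identity of the ring, even though the heavy-atom count and the donor and acceptor counts stay the same. Nothing available explains why the step is so large.

The exchange alters the ring's aromaticity and its point of attachment together, so the compounds shown leave open which of the two accounts for the step. A furan-3-yl group, or an oxolan-2-yl group, at the same place on the core of compound 3 would separate these two changes.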